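Methoxymethyl for trifluoromethyl on the shared core

The source may hold more compounds than are shown below. What is called first, only, known or untested is meant among the compounds shown, and "the series" means these compounds.

Measured so far in an in vitro ADME assay on microsomes from liver (Homo sapiens) for metabolic stability (on this read-out lower numbers stand for slow clearance and higher numbers for fast clearance), with these readings:
- compound 1 (`CCc1nc2nc(C)cc(Nc3cccc(Cl)c3)n2n1`) gives 78.3 mL.min-1.g-1 as a number
- compound 2 (`Cc1cc(Nc2ccc(S(F)(F)(F)(F)F)cc2)n2nc(C(F)(F)F)nc2n1`) gives < 5 mL.min-1.g-1 as a limit of the assay and not a number
- compound 3 (`CCOc1nc2nc(C)cc(Nc3ccc(C(F)(F)F)cc3)n2n1`) gives 7 mL.min-1.g-1 as a number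

Compound 2 stands at the limit of < 5 mL.min-1.g-1 in this assay, at which 1 of the 3 values shown sits, in this set. That reading is a limit and not a number.

The next step keeps the rest of compound 2 and leads to compound 4 (`COCc1nc2nc(C)cc(Nc3ccc(S(F)(F)(F)(F)F)cc3)n2n1`), with methoxymethyl in place of trifluoromethyl on an aromatic carbon. Among the compounds with values here, no pair of measured compounds differs in one place only, so the expectation rests on whole compounds. Compound 3 also lacks trifluoromethyl on that carbon and gives 7 mL.min-1.g-1 in this assay as the nearest guide. Compound 1 gives 78.3 mL.min-1.g-1 in this assay and marks the fast end of the readings so far. A moderate rise towards faster clearance is expected, beyond the usual scatter, and the estimated step is an at least 2.8-fold higher number from compound 2 to compound 4 (0.44 log units; beyond the scatter) on that basis. In this assay compound 4 is expected at 14 mL.min-1.g-1 within an estimated range of 5 mL.min-1.g-1 to 40 mL.min-1.g-1 for now.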

Compound 4, intrinsic clearance in microsomes: 5.6 mL.min-1.g-1
Estimate against measurement, compound 4: 2.5-fold (0.40 log units) above; low and high end bracket the measured number.
By their numbers in this assay, from the lowest: compounds 4 and 3 (each within the scatter of the next); then compound 1. At a limit, below all of these: compound 2.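

Within the data shown here, at this position, an aromatic carbon of a five-membered aromatic ring with 3 nitrogen, methoxymethyl in place of trifluoromethyl gives in this assay the first step that can be read: an at least 1.1-fold higher number from compound 2 to compound 4 (0.04 log units; that floor lies within the scatter). The reading of compound 2 is a limit of the assay and not a number: the limit of < 5 mL.min-1.g-1 in this assay, at which 1 of the 4 values shown sits. With the rest of compound 2 kept, compound 4 gives 5.6 mL.min-1.g-1, so trifluoromethyl on this carbon is not required for a low number in this assay, and the exchange brings in a hydrogen-bond acceptor without a step beyond the scatter being shown.

Going by these compounds, how far compound 2 lies under its limit stays open, so the step has a floor only and its true size cannot be stated. Also open, on these data alone, is whether an amine, a carboxylic acid or a longer chain such as ethoxymethyl on this carbon, with the rest of compound 4 unchanged, would hold a number this low in this assay.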